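The source may report more compounds than this note shows. Statements on the series, on what has been measured and on what is new or still open speak of the compounds shown alone.

The measured compounds in a functional assay on Huh-7 cells (Homo sapiens) for inhibition, read by MTT assay, with a stated time of 48 h; on this read-out higher numbers stand for weaker inhibition and lower numbers for stronger inhibition:
Compound 1 `COc1cc2ccc(=O)oc2cc1OC(=O)c1c(C)noc1-c1ccc(Cl)cc1` gives 12400 nM.
Compound 2 `COc1cc2ccc(=O)oc2cc1OC(=O)c1c(C)noc1-c1ccccc1` gives > 25000 nM, which is a limit of this assay and not a number.
Compound 3 `COc1cc2ccc(=O)oc2cc1OC(=O)c1c(-c2ccc(Cl)cc2)n[nH]c1C` gives 16200 nM.

Compound 3 and compound 1 sit within the usual scatter of each other, so their two numbers cannot be told apart. The remaining value, that of compound 2, is the limit of > 25000 nM in this assay, at which 1 of the 3 values shown sits.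

Compound 4 `COc1cc2ccc(=O)oc2cc1OC(=O)c1c(-c2ccc([N+](=O)[O-])cc2)n[nH]c1C` differs from compound 3 by nitro in place of chloro on an aromatic carbon. For the measured compounds named here, the only measured step, an at least 2.0-fold higher number from compound 1 to compound 2 (0.30 log units; that floor lies within the scatter), removes the chloro and leaves hydrogen, on a shared core that is not the core of compound 3; it ends at a limit, so its true size is unknown. Going by the values given here, no measured step exchanges chloro for nitro, and the nitro is a different group from hydrogen, so that step is only a loose guide. Compound 4 keeps a group in the same place, and the expected step is a 1.1-fold higher number from compound 3 to compound 4 (0.05 log units; within the scatter), not beyond the scatter. Compound 4 is therefore estimated to give about 18000 nM in this assay, between 8000 nM and 40000 nM.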

Compound 4, half-maximal inhibitory concentration: > 25000 nM
Compound 4 was reported as a limit; the forecaster's own chance of this, stated with the estimate: 30%; middle value at least 1.3-fold (0.14 log units) away from the limit.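

In this assay, nitro in place of chloro on the aromatic ring gives an at least 1.5-fold higher number from compound 3 to compound 4 (0.18 log units; that floor lies within the scatter). The value of compound 4 is a limit of the assay and not a number, and compound 2 shares it: the limit of > 25000 nM in this assay, at which 2 of the 4 values shown sit. The earlier compounds showed only hydrogen replacing chloro, on the core of compound 1; now a larger group, on the core of compound 3, also ends at the limit, so among these four compounds only the two carrying chloro give numbers.

Going by these compounds, the true size of the step stays unknown, so it cannot be said whether it goes beyond the scatter. Also open, on these data alone, is whether hydrogen, an amine or a methoxy group in this place on the core of compound 3 would give a number, as chloro does.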